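The source may hold more compounds than are shown below. What is called first, only, known or untested is meant among the compounds shown, and "the series" means these compounds.

Measured in a functional assay on OVCAR-3 cells (Homo sapiens) for cytotoxicity, read by sulforhodamine B assay; on this read-out lower numbers stand for stronger inhibition of growth and higher numbers for weaker inhibition of growth:
- Compound 1 `CC1=CC[C@@H]([C@@](C)(O)CCCC(C)(C)NC(=S)N/N=C\c2ccc(C)cc2)CC1`: 6020 nM
- Compound 2 `CC1=CC[C@@H]([C@@](C)(O)CCCC(C)(C)NC(=S)N/N=C\c2ccccc2[N+](=O)[O-])CC1`: 7390 nM

For the measured compounds named here, compound 1 stands level with compound 2, the only other measured compound, since the two lie within the scatter of each other. Compound 3 `CC1=CC[C@@H]([C@@](C)(O)CCCC(C)(C)NC(=S)N/N=C(/C)c2ccccc2)CC1` differs from compound 1 as follows: a group of 9 heavy atoms (8 carbon, 1 nitrogen; one six-membered aromatic ring of carbon only) in place of a group of 9 heavy atoms (8 carbon, 1 nitrogen; one six-membered aromatic ring of carbon only), on an amide-type nitrogen. Going by the values given here, only one measured step bears on this change, as it also alters the aryl part of the group: a 1.2-fold higher number from compound 1 to compound 2 (0.09 log units; within the scatter). That step stays within the scatter, so no shift beyond the scatter is expected in this assay, and the expected step is a 1.1-fold higher number from compound 1 to compound 3 (0.03 log units; within the scatter). The estimated value for compound 3 is 6500 nM, with an expected range of 3000 nM to 14000 nM.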

Compound 3, concentration for 50% growth inhibition: 14300 nM
Compound 3: middle estimate off by 2.2-fold (0.34 log units), on the low side, and the stated range ends below it.
By their numbers in this assay, from the lowest: compounds 1, 2 and 3 (each within the scatter of the next, the first and the last beyond it).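

In this assay, joining the same atoms differently within the group on the amide-type nitrogen gives a 2.4-fold higher number from compound 1 to compound 3 (0.38 log units; beyond the scatter), a modest shift beyond the scatter. For the compounds shown here, the only earlier step, a 1.2-fold higher number from compound 1 to compound 2 (0.09 log units; within the scatter), stayed within the scatter, so this position proved responsive to a change that leaves the composition of the group intact. Nothing available explains this shift. The compounds shown leave open how a pyridine ring, an amine or a carboxylic acid in this group would behave in this assay.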